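Swapping a sulfur-bearing group for a small carbon ring

A few compounds are considered here, and "the series" means these few. Any claim that something is new, unique, unknown or untested is made for them only; others in the source may bear on it.

Measured compounds and their values:
- compound 1 `Nc1ncc(-c2cc([C@H]3CCCO3)nc(N3C[C@@H]4C[C@H]3CO4)n2)nc1OC(F)F` gives 202 nM
- compound 2 `Nc1ncc(-c2cc(N3C[C@@H]4C[C@H]3CO4)nc(N3CC4CC3C4)n2)nc1OC(F)F` gives 7 nM
- compound 3 `CCOC(=O)N1C[C@@H]2C[C@H]1CN2c1nc(SC)cc(-c2cnc(N)c(OC(F)F)n2)n1` gives 44 nM

These three compounds were tested in an assay on Sf21 cells for inhibition of mitogen-activated protein kinase kinase kinase 13 (Homo sapiens), read by HTRF, with a stated time of 1.5 h; a lower number here means a stronger inhibitor, a higher number a weaker inhibitor. Among them, compound 3 stands second highest of the three numbers: compound 1 has the higher number, beyond the scatter, and compound 2 has the lower number, also beyond the scatter. Among the compounds with values here, no pair of these three differs in only one place, so no single step between them can be read off.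

Compound 4 `CCOC(=O)N1C[C@@H]2C[C@H]1CN2c1nc(-c2cnc(N)c(OC(F)F)n2)cc(C2CC2)n1` has not yet been measured in this assay. It differs from compound 3 in one place: cyclopropyl in place of methylsulfanyl on an aromatic carbon. The change is on an aromatic carbon of a six-membered aromatic ring with two nitrogen atoms, a position described as meta to two large groups and opposite the ring nitrogen.

Within the data shown here, with no comparable step among the measured compounds, the expected step from compound 3 to compound 4 in this assay is a 1.1-fold higher number from compound 3 to compound 4 (0.06 log units; within the scatter), that is, none beyond the scatter. Compound 4 is therefore estimated at 50 nM, within a range from 15 nM to 160 nM.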

Compound 4, half-maximal inhibitory concentration: 45 nM
Estimate against measurement, compound 4: 1.1-fold (0.05 log units) above, and the stated range covers the measured number.
By their numbers in this assay, from the lowest: compound 2; then compounds 3 and 4 (each within the scatter of the next); then compound 1.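

Within this assay, this is the only comparison shown in which two compounds differ in just one place, and it gives a 1.0-fold higher number from compound 3 to compound 4 (0.01 log units; within the scatter). Cyclopropyl can therefore take the place of methylsulfanyl on this aromatic carbon, opposite the ring nitrogen, with no change beyond the scatter, even though sulfur and a hydrogen-bond acceptor leave and a three-membered carbon ring enters. Nothing measured here explains why the two groups give matching numbers.

Among the compounds shown, only these two groups sit at this position, so it remains open whether an amine, a methoxy group or a longer chain such as propyl would give a similar number. Going by these compounds, it also remains open whether this swap would give the same result with different groups elsewhere on the core.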